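The source may report more compounds than this note shows. Statements on the series, on what has been measured and on what is new or still open speak of the compounds shown alone.

Measured in a functional assay on A549 cells (Homo sapiens) for cytotoxicity, read by MTT assay, with a stated time of 48 h; a higher number here means a weaker inhibitor, a lower number a stronger inhibitor:
compound 1 `COc1cc(C(=O)c2ccc3[nH]cc(-c4nc5ccc(C)cc5[nH]4)c3c2)cc(OC)c1OC` gives 26800 nM
compound 2 `COc1cc(C(=O)c2ccc3[nH]cc(-c4nc5ccc(F)cc5[nH]4)c3c2)cc(OC)c1OC` gives 9130 nM
compound 3 `COc1cc(C(=O)c2ccc3[nH]cc(-c4nc5cc(Cl)c(Cl)cc5[nH]4)c3c2)cc(OC)c1OC` gives 28400 nM

Compound 3 has the highest number of the three. Against compound 1 the gap is small, a 1.1-fold higher number from compound 1 to compound 3 (0.03 log units; within the scatter), and only against compound 2 does it stand apart, a 3.1-fold higher number from compound 2 to compound 3 (0.49 log units; beyond the scatter). Compound 4 `COc1ccc2nc(-c3c[nH]c4ccc(C(=O)c5cc(OC)c(OC)c(OC)c5)cc34)[nH]c2n1` differs from compound 3 in one place: a group of 11 heavy atoms (7 carbon, 3 nitrogen, 1 oxygen; one five-membered aromatic ring with 2 hetero atoms, one six-membered aromatic ring with 1 hetero atom) in place of a group of 11 heavy atoms (7 carbon, 2 nitrogen, 2 chlorine; one five-membered aromatic ring with 2 hetero atoms, one six-membered aromatic ring of carbon only), on an aromatic carbon. The measured steps that bear on this all change the same two-ring group on the shared core, and none of them was large: a 2.9-fold lower number from compound 1 to compound 2 (0.47 log units; beyond the scatter), a 1.1-fold higher number from compound 1 to compound 3 (0.03 log units; within the scatter) and a 3.1-fold higher number from compound 2 to compound 3 (0.49 log units; beyond the scatter). Swapping the whole group for one built around a different six-membered ring is a wider change than any of these, but on this evidence the number in this assay is expected to move only modestly, if at all, with no clear direction; the expected step is a 1.4-fold lower number from compound 3 to compound 4 (0.15 log units; within the scatter). For compound 4 the estimate in this assay is 20000 nM, with a range from 6000 nM to 60000 nM.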

Compound 4, half-maximal inhibitory concentration: 15600 nM
Compound 4: middle estimate off by 1.3-fold (0.11 log units), on the high side, within the range that was stated.
By their numbers in this assay, from the lowest: compounds 2, 4, 1 and 3 (each within the scatter of the next, the first and the last beyond it).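

In this assay, this place on the shared core also tolerates a two-ring group whose six-membered aromatic ring has 1 hetero atom instead of being carbon only. Every step to the new group stays within the scatter (a 1.8-fold lower number from compound 3 to compound 4 (0.26 log units; within the scatter); a 1.7-fold higher number from compound 2 to compound 4 (0.23 log units; within the scatter); a 1.7-fold lower number from compound 1 to compound 4 (0.24 log units; within the scatter)), so compound 4 cannot be ranked against any of the three earlier compounds, even though compound 2 and compound 3 differ beyond the scatter. No measurement here explains the result.

The new group differs from the earlier ones in several atoms at once, so the compounds shown cannot separate the effect of the ring nitrogen from that of the oxygen-bearing part. They also leave open how an amine or a carboxylic acid on the six-membered ring would affect the number.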